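The source may report more compounds than this note shows. Statements on the series, on what has been measured and on what is new or still open speak of the compounds shown alone.

Compound 1 `COc1ccc(C(=O)C=CNc2cc(-c3ccccc3)nn2-c2ccccc2)cc1` and compound 2 `O=C(C=CNc1cc(-c2ccccc2)nn1-c1ccccc1)c1ccccc1` share one core and differ in a single spot. In a functional assay on MCF7 cells (Homo sapiens) for inhibition, read by MTT assay, with a stated time of 48 h (a higher number here means a weaker inhibitor, a lower number a stronger inhibitor), compound 1 gives 1290 nM, and compound 2 gives 9650 nM. The change between them is hydrogen in place of methoxy on an aromatic carbon, and it produced a 7.5-fold higher number from compound 1 to compound 2 (0.87 log units; beyond the scatter), so removing the methoxy made the compound a weaker inhibitor.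

Compound 3 `COc1ccc(-c2nc3c(c(-c4ccccc4)nn3-c3ccccc3)c(-c3ccc(N4CCN(C)CC4)cc3)c2C#N)cc1` is built on a different, larger core; how its core differs from that of compound 1 is not broken down here. In this assay compound 3 gives 2650 nM, a number that lies between those of compound 1 and compound 2.

Compound 4 `CN1CCN(c2ccc(-c3c(C#N)c(-c4ccccc4)nc4c3c(-c3ccccc3)nn4-c3ccccc3)cc2)CC1` has not yet been measured. For the measured compounds named here, it differs from compound 3 by hydrogen in place of methoxy on an aromatic carbon, which is the same change as the one from compound 1 to compound 2, made at the same kind of place. In this assay compound 4 is therefore expected to be a weaker inhibitor than compound 3, with the estimated step being a 2.6-fold higher number from compound 3 to compound 4 (0.42 log units; beyond the scatter). This expectation rests on the measured result for compound 1 and compound 2, where the same change gave a 7.5-fold higher number from compound 1 to compound 2 (0.87 log units; beyond the scatter); since the surrounding core of compound 3 is different, a somewhat smaller step is assumed, and the range is kept wide. The estimated value for compound 4 is 7000 nM, expected to fall between 2500 nM and 20000 nM.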

Compound 4, half-maximal inhibitory concentration: 14300 nM
Beside the measured number, compound 4's estimate is 2.0-fold (0.31 log units) below it; measured number inside the range.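

Replacing the methoxy with hydrogen weakened the compound on the larger core too, and in this assay this gave a 5.4-fold higher number from compound 3 to compound 4 (0.73 log units; beyond the scatter). Set beside the earlier result, the two steps point the same way and cannot be told apart in size: the same change on two cores in this assay, a 7.5-fold higher number (0.87 log units; beyond the scatter) from compound 1 to compound 2 and a 5.4-fold higher number (0.73 log units; beyond the scatter) from compound 3 to compound 4, 1.4-fold (0.14 log units) apart, within the scatter of two such steps. So within these two pairs, the change from 4-methoxyphenyl to phenyl carried over from one core to the other and could be read as a similar step on both, but two pairs cannot show that it would hold on a third core, and these numbers alone do not explain how the methoxy produces its effect.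

The compounds shown compare only methoxy and hydrogen at this place on the ring, so they leave open whether a different group there, such as a hydroxyl, an ethoxy, a chlorine or an amine, would give a stronger or weaker inhibitor than methoxy. They also leave open whether a methoxy at another place on that ring would give a similar step, and whether the same step would appear in a cell line other than the one used here.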